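Furan-2-yl in place of 1H-pyrrol-2-yl: expected step

The source may report more compounds than this note shows. Statements on the series, on what has been measured and on what is new or still open speak of the compounds shown alone.

compound 1 `O=C(/C=C/c1ccccc1)c1ccc[nH]1`: > 100000 nM (a limit)
compound 2 `O=C(/C=C/c1ccc([N+](=O)[O-])cc1)c1ccc[nH]1`: 13000 nM

In a functional assay on PC-3 cells (Homo sapiens) for inhibition, read by MTT assay, with a stated time of 48 h (a lower number here means a stronger inhibitor, a higher number a weaker inhibitor), compound 1 is known only through a limit, > 100000 nM, and has no number of its own. Compound 3 `O=C(/C=C/c1ccccc1)c1ccco1` carries furan-2-yl in place of 1H-pyrrol-2-yl on a carbonyl carbon. Among the measured compounds shown here, the only measured step, an at least 7.6-fold lower number from compound 1 to compound 2 (0.88 log units; beyond the scatter), is a different change, nitro in place of hydrogen on an aromatic carbon, so it offers no more than a rough size for a single change. A smaller step is expected here. With compound 1 at a limit, the only direction open to a reported number is toward a lower one. The estimate amounts to an expected at least 1.6-fold lower number from compound 1 to compound 3 (0.22 log units; that floor lies within the scatter). The estimate for compound 3 is 60000 nM, with an expected range of 20000 nM to 150000 nM.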

Compound 3, half-maximal inhibitory concentration: > 100000 nM
Compound 3 was reported as a limit (the forecaster's own chance of this, stated with the estimate: 55%); middle value at least 1.6-fold (0.22 log units) away from the limit.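

In this assay, no step can be read between compound 1 and compound 3, because both are reported only as limits: the limit of > 100000 nM in this assay, at which 2 of the 3 values shown sit.

The compounds shown leave open how furan-2-yl and 1H-pyrrol-2-yl on a carbonyl carbon compare in this assay.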